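A few compounds are considered here, and "the series" means these few. Any claim that something is new, unique, unknown or untested is made for them only; others in the source may bear on it.

Measured so far in the series:

Compound 1, `Cn1ncc2cc(-c3ccc4oc(NC5CCCCC5)nc4c3)ccc21` — in an assay on HEK293 cells for inhibition of Fatty-acid amide hydrolase 1 (Homo sapiens), read by fluorescence (a higher number here means a weaker inhibitor, a lower number a stronger inhibitor), compound 1 gives 61 nM.
Compound 2, `Cn1ccc2cc(-c3ccc4oc(Cc5ccccc5)nc4c3)ccc21` — in this assay compound 2 gives 488 nM.

Within the data shown here, compound 2 holds the highest of the two numbers so far. Its nearest neighbour is compound 1, whose value is lower by a margin that goes beyond the scatter of repeated measurements. Among the measured compounds shown here, no single-point step between the two measured compounds is available, since they differ in more than one place, so nothing about the size of any isolated change can be read from them directly.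

Compound 3, `CNc1nc2cc(-c3ccc4c(ccn4C)c3)ccc2o1`, is not yet measured. Relative to compound 2 the change is methylamino in place of benzyl on an aromatic carbon. For the measured compounds named here, the one measured compound carrying an amino substituent on the shared core, compound 1, gives the lower number at 61 nM. On that basis a downward step in this assay is expected for compound 3, moderate in size and likely beyond the scatter, though without a matched pair this remains an expectation only. The step from a 3.3-fold lower number from compound 2 to compound 3 (0.51 log units; beyond the scatter) is the estimated outcome. Compound 3 is therefore expected to come in near 150 nM, with a plausible range from 40 nM to 600 nM.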

Compound 3, half-maximal inhibitory concentration: > 1000 nM
Compound 3: only a limit was reported (the forecaster's own chance of this, stated with the estimate: 5%); middle value at least 6.6-fold (0.82 log units) from the limit.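

Compound 3 reads > 1000 nM in this assay, and this is a limit of the assay, not a number. The series now has its first step in a single place, on the aromatic carbon next to the ring nitrogen and next to the ring oxygen: methylamino in place of benzyl gives an at least 2.0-fold higher number from compound 2 to compound 3 (0.31 log units; beyond the scatter), so the change at this carbon moves the number upward, towards weaker inhibition. Only a lower bound can be given for the size of that step, because the reading for compound 3 stops at a limit: the limit of > 1000 nM in this assay, at which 1 of the 3 values shown sits.

The swap removes the carbocyclic aromatic ring and changes the linking atom together, so the step cannot assign the loss to either change alone; a phenylamino group at the same carbon would keep the ring while carrying the amino link. Going by these compounds, compound 1 differs from compound 3 in more than one place, so whether the cyclohexyl group on its amino link matters at this carbon remains open, and a longer alkylamino chain on the core of compound 3 would bear on that question.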